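Replacing fluoro with hydroxy in compound 3

The compounds below may be only part of what the source reports. "The series", "measured", "known", "first", "only" and "open" are said of these compounds alone.

Of the compounds shown here, three have so far been measured in an ADME assay on HEp-2 cells (Homo sapiens) for cytotoxicity; on this read-out lower numbers stand for higher toxicity in this test and higher numbers for lower toxicity in this test. Compound 1 (`CC(C)CCn1c(CN2C(=O)CSc3ccccc32)nc2ccccc21`) gives 6780 nM, compound 2 (`CC(C)CCn1c(CN2C(=O)N(CC(=O)O)S(=O)(=O)c3ccccc32)nc2ccccc21`) gives 60200 nM, and compound 3 (`CN1C(=O)N(Cc2nc3ccccc3n2CCCCF)c2ccccc2S1(=O)=O`) gives 87700 nM. Compound 3 therefore stands at the top of this small set together with compound 2, since the two are level within the scatter, while compound 1 lies clearly lower.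

Compound 4 (`CN1C(=O)N(Cc2nc3ccccc3n2CCCCO)c2ccccc2S1(=O)=O`) is compound 3 with a single change: hydroxy in place of fluoro on a saturated chain carbon, four bonds along the chain from an aromatic nitrogen. This puts hydroxy in place of fluoro on a saturated chain carbon, four bonds along the chain from an aromatic nitrogen. Among the measured compounds shown here, no two measured compounds differ in only one place, so the data give no direct guide to this swap, and no step beyond the scatter is expected in this assay. The expected change, a 1.0-fold higher number from compound 3 to compound 4 (0.01 log units; within the scatter), is estimated to stay within the scatter. For compound 4 the estimated value is 90000 nM, with an expected range from 40000 nM to 190000 nM.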

Compound 4, half-maximal cytotoxic concentration: 219000 nM
Beside the measured number, compound 4's estimate is 2.4-fold (0.39 log units) below it; measured number outside the range, above it.
By their numbers in this assay, from the lowest: compound 1; then compounds 2 and 3 (each within the scatter of the next); then compound 4.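

In this assay the swap of fluoro for hydroxy on a saturated chain carbon, four bonds along the chain from an aromatic nitrogen, gives a 2.5-fold higher number from compound 3 to compound 4 (0.40 log units; beyond the scatter) and so points towards lower toxicity in this test. Among the compounds shown here, this is the only single-place comparison in the set, and it shows that exchanging one heavy atom at this position can move the number modestly beyond the usual scatter. Nothing shown explains the rise, and this one pair cannot link it to the hydrogen-bond donor and acceptor that enter with the hydroxy.

From the compounds shown here alone, it remains open whether an amine, a carboxylic acid or a methoxy group at this position would move the number in the same direction. It is also unclear whether the hydroxy would have the same effect on a longer chain.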